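A few compounds are considered here, and "the series" means these few. Any claim that something is new, unique, unknown or untested is made for them only; others in the source may bear on it.

Compound 1 `CC(C)(C)[C@@]1(c2ccccc2)OCC[C@@H](CCN)O1` and compound 2 `C[C@]1(c2ccccc2)OCC[C@H](CCN)O1` both carry an amine bearing only hydrogen, but on different cores; the difference between the two cores is not broken down here. In an assay on brain for displacement of a labelled ligand from Sigma non-opioid intracellular receptor 1 (Cavia porcellus) (on this read-out lower numbers stand for stronger inhibition and higher numbers for weaker inhibition), compound 1 gives only a limit of the assay, > 10000 nM. In this assay compound 2 also gives only a limit of the assay, > 10000 nM. Compound 3 `C[C@]1(c2ccccc2)OCC[C@H](CCNCc2ccccc2)O1` is compound 2 with one change: benzyl in place of hydrogen on an amine nitrogen. In this assay compound 3 gives 11 nM. That single change produced an at least 900-fold lower number from compound 2 to compound 3 (2.95 log units; beyond the scatter), and the size of this step can be given only as a lower bound due to the limit of > 10000 nM in this assay, at which 2 of the 3 values shown sit.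

Compound 4 `CC(C)(C)[C@@]1(c2ccccc2)OCC[C@@H](CCNCc2ccccc2)O1` is compound 1 carrying the same change: benzyl in place of hydrogen on an amine nitrogen. The surroundings of the place where benzyl enters are the same word for word in both pairs, so this is the same change, made on the core of compound 1 rather than that of compound 2. Compound 4 is expected to show an at least 250-fold lower number from compound 1 to compound 4 (2.39 log units; beyond the scatter). Among the compounds with values here, this expectation rests on the step of an at least 900-fold lower number from compound 2 to compound 3 (2.95 log units; beyond the scatter), the only measured instance of this change, while the cores of compound 1 and compound 2 differ in a way that remains unresolved, which widens the range. The estimate for compound 4 in this assay is 40 nM, with a range from 8 nM to 300 nM.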

Compound 4, inhibition constant: 128 nM
Compound 4: middle estimate off by 3.2-fold (0.51 log units), on the low side; low and high end bracket the measured number.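

In this assay, the change that worked on the core of compound 2 also works on the core of compound 1, and the step here is again large: an at least 78-fold lower number from compound 1 to compound 4 (1.89 log units; beyond the scatter). So on both cores shown, benzyl on the amine nitrogen goes with a far lower number than hydrogen in that place, but whether the change is worth the same on each core cannot be told: the same change on two cores in this assay, an at least 900-fold lower number (2.95 log units; beyond the scatter) from compound 2 to compound 3 and an at least 78-fold lower number (1.89 log units; beyond the scatter) from compound 1 to compound 4; the limit leaves it open whether they differ Neither step has a known full size, and two pairs on two cores make no rule for the whole series, because each step starts from a value that is only a limit: the limit of > 10000 nM in this assay, at which 2 of the 4 values shown sit.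

The compounds shown leave open how much of the effect needs the whole benzyl group, a question that a methyl group on the same nitrogen, or a cyclohexylmethyl group with a saturated ring in place of the aromatic one, could begin to answer. They also leave open whether a longer chain between the nitrogen and the phenyl ring, as in phenylethyl, would keep the low numbers on either core.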